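This account rests on a few compounds, and the source may have more. Where it says the series, first, only, none or still open, it means among the compounds named here.

Compound 1 `CC(C(=O)NCc1ccc(C(F)(F)F)nc1Cl)c1ccc(NS(C)(=O)=O)c(F)c1` gives 0.2 nM in an assay on CHO cells for antagonist activity at transient receptor potential cation channel subfamily V member 1 (Homo sapiens), read by FLIPR and calcium flux; on this read-out lower numbers stand for stronger inhibition and higher numbers for weaker inhibition. Compound 3 `CC(C(=O)NCc1ccc(C(F)(F)F)nc1C1=CCC(C(C)(C)C)CC1)c1ccc(NS(C)(=O)=O)c(F)c1` gives 0.2 nM in this assay, level with compound 1 at the digits shown, and compound 2 `CCC1CCC(c2nc(C(F)(F)F)ccc2CNC(=O)C(C)c2ccc(NS(C)(=O)=O)c(F)c2)CC1` gives 0.3 nM, within the scatter of both. Swapping out the chloro on the shared core has so far changed little: a 1.5-fold higher number from compound 1 to compound 2 (0.18 log units; within the scatter), no change at the digits printed from compound 1 to compound 3 (within the scatter) and a 1.5-fold lower number from compound 2 to compound 3 (0.18 log units; within the scatter). Compound 4 `CC(C)=Cc1nc(C(F)(F)F)ccc1CNC(=O)C(C)c1ccc(NS(C)(=O)=O)c(F)c1` differs from compound 1 by 2-methylprop-1-en-1-yl in place of chloro on an aromatic carbon. The two measured steps that also replace the chloro on an aromatic carbon bear on this change, and neither moved beyond the scatter, so no step beyond the scatter is expected in this assay. For compound 4 the expected value is 0.25 nM (range 0.1 nM to 0.7 nM), an expected step of a 1.3-fold higher number from compound 1 to compound 4 (0.10 log units; within the scatter).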

Compound 4, inhibition constant: 11.5 nM
Compound 4: the middle estimate sits 46-fold (1.66 log units) below what was measured; measured number outside the range, above it.
By their numbers in this assay, from the lowest: compounds 1, 3 and 2 (each within the scatter of the next); then compound 4.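

In this assay this position proves far from indifferent to what replaces the chloro, with a 58-fold higher number from compound 1 to compound 4 (1.76 log units; beyond the scatter) and a 58-fold higher number from compound 3 to compound 4 (1.76 log units; beyond the scatter) and a 38-fold higher number from compound 2 to compound 4 (1.58 log units; beyond the scatter) once 2-methylprop-1-en-1-yl stands there. Among the carbon groups at this position, the two carrying a ring stay level with the chloro and the one without a ring does not, a contrast resting on compounds 2, 3 and 4 alone. Nothing at hand accounts for the loss.

The compounds shown leave open whether a saturated chain such as isobutyl or an amine such as pyrrolidine at this position would read like compound 1 or like compound 4.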